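This account rests on a few compounds, and the source may have more. Where it says the series, first, only, none or still open, it means among the compounds named here.

Compound 1 `CC(C)=CCc1cc(C(=O)Nc2cc3ccc(OCCCN4CCCCC4)c(C)c3oc2=O)ccc1O`: > 50000 nM
Compound 2 `CC(C)=CCc1cc(C(=O)Nc2cc3ccc(OCCCN4CCCC4)c(C)c3oc2=O)ccc1O`: 720 nM
Compound 3 `CCN(C)CCCOc1ccc2cc(NC(=O)c3ccc(O)c(CC=C(C)C)c3)c(=O)oc2c1C`: 730 nM

In a functional assay on SK-BR-3 cells (Homo sapiens) for antiproliferative activity (a lower number here means a stronger inhibitor, a higher number a weaker inhibitor), compound 3 gives 730 nM. The a 1.0-fold higher number from compound 2 to compound 3 (0.01 log units; within the scatter) lies within the scatter, so compound 2 and compound 3 stand level. Compound 1 gives > 50000 nM, which is a limit of the assay and not a number.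

Compound 4 `CCN(CC)CCCOc1ccc2cc(NC(=O)c3ccc(O)c(CC=C(C)C)c3)c(=O)oc2c1C` carries one change, methyl in place of hydrogen on a saturated chain carbon bound to an amine nitrogen, so that ethyl(methyl)amino becomes diethylamino.

All three measured steps alter this same amine group. Two were large: an at least 69-fold lower number from compound 1 to compound 2 (1.84 log units; beyond the scatter) and an at least 68-fold lower number from compound 1 to compound 3 (1.83 log units; beyond the scatter). The amine can therefore matter a great deal, yet swapping pyrrolidin-1-yl for ethyl(methyl)amino changed nothing beyond the scatter. Compound 4 keeps an amine without a ring, as compound 3 does, so little change is expected, with some risk of a larger loss towards the weak side.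

The expected step is a 1.4-fold higher number from compound 3 to compound 4 (0.14 log units; within the scatter).

For compound 4 the estimated value is 1000 nM, with an expected range of 350 nM to 6000 nM.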

Compound 4, half-maximal inhibitory concentration: 4900 nM
Estimate against measurement, compound 4: 4.9-fold (0.69 log units) below; the range from low to high includes it.
By their numbers in this assay, from the lowest: compounds 2 and 3 (each within the scatter of the next); then compound 4. At a limit, above all of these: compound 1.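

Adding one methyl on a saturated chain carbon bound to an amine nitrogen, which turns ethyl(methyl)amino into diethylamino, gives a 6.7-fold higher number from compound 3 to compound 4 (0.83 log units; beyond the scatter), and the comparison with the ring amine gives a 6.8-fold higher number from compound 2 to compound 4 (0.83 log units; beyond the scatter), so this position responds to a single added carbon even though compounds 2 and 3 stood level. Diethylamino still compares well with piperidin-1-yl, with an at least 10-fold lower number from compound 1 to compound 4 (1.00 log units; beyond the scatter). That step is only a bound, because compound 1 sits at a limit of the assay and not at a number: the limit of > 50000 nM in this assay, at which 1 of the 4 values shown sits.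

Among these compounds, whether the loss grows steadily as carbons are added to the amine stays open, since two open-chain amines give only one step. Dimethylamino and dipropylamino would extend this series on either side, and morpholin-4-yl would test another ring in place of pyrrolidin-1-yl and piperidin-1-yl.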